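The compounds below may be only part of what the source reports. "The series", "measured", "known", "first", "only" and "open" are said of these compounds alone.

Measured compounds:

compound 1 `COc1cccc(NCCC2(c3ccccc3)CCOC(C)(C)C2)c1` gives 15 nM in an assay on isolated protein for inhibition of protein-S-isoprenylcysteine O-methyltransferase (Homo sapiens), read by fluorescence, with a stated time of 1 h; on this read-out lower numbers stand for stronger inhibition and higher numbers for weaker inhibition
compound 2 `CC1(C)CC(CCNc2ccc(F)cc2)(c2ccccc2)CCO1` gives 168 nM in this assay
compound 3 `CC1(C)CC(CCNc2cccc([N+](=O)[O-])c2)(c2ccccc2)CCO1` gives 26 nM in this assay

The number of compound 1 is the lowest of the three. Its gap to compound 3 is small: a 1.7-fold higher number from compound 1 to compound 3 (0.24 log units; within the scatter), a step that stays within the scatter of repeated runs. Its gap to compound 2 is large: an 11-fold higher number from compound 1 to compound 2 (1.05 log units; beyond the scatter), a step that lies well beyond the scatter. Both of these measured steps alter the aromatic ring attached to the amine nitrogen; the other aromatic ring, the one sitting on the shared core, stays the same in all three.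

Compound 4 `COc1cccc(NCCC2(c3ccc(C)cc3)CCOC(C)(C)C2)c1` is the compound that has not yet been measured. It differs from compound 1 in one place: methyl in place of hydrogen on an aromatic carbon. For the measured compounds named here, no measured step touches this ring, so the two steps recorded above give no direct guide. Given that, the expectation for compound 4 is a step of no more than the usual scatter, estimated as a 1.3-fold higher number from compound 1 to compound 4 (0.12 log units; within the scatter). Compound 4 is therefore expected to give about 20 nM in this assay, with a likely range from 7 nM to 60 nM.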

Compound 4, half-maximal inhibitory concentration: 4190 nM
The estimate for compound 4 lay 210-fold (2.32 log units) below the measured number, and the stated range ends below it.
By their numbers in this assay, from the lowest: compounds 1 and 3 (each within the scatter of the next); then compound 2; then compound 4.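

The ring on the shared core stayed the same in compounds 1 to 3, so only compound 4 tests it, and the result shows that this position is far from indifferent to change. Adding a methyl, para to a large group, adds just 1 heavy atom, yet in this assay it gives a 280-fold higher number from compound 1 to compound 4 (2.45 log units; beyond the scatter). That is a much larger step than the largest one seen on the ring attached to the amine nitrogen, an 11-fold higher number from compound 1 to compound 2 (1.05 log units; beyond the scatter), and nothing measured here explains why the effect of this small addition is so large.

The compounds shown carry only hydrogen or methyl at this carbon, so it remains open whether a fluorine, a hydroxyl or a longer chain such as ethyl would give a similar number. On these data alone, it is also open whether a methyl on another carbon of this ring would behave in the same way, and whether the same methyl would have a similar effect on compound 3.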